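The compounds below may be only part of what the source reports. "The series", "measured", "known", "first", "only" and "open" are said of these compounds alone.

Of the compounds shown here, three built on one shared core have been measured in a physicochemical assay for lipophilicity; on this read-out higher numbers stand for higher lipophilicity and lower numbers for lower lipophilicity. Compound 1 `COc1ccc(C2=NO[C@]3(C2)C(=O)O[C@@H]2[C@H]3CC[C@H](C)[C@]3(O)C=CC(=O)[C@@]23C)cc1` gives 1.47. Among the measured compounds shown here, compound 2 `C[C@H]1CC[C@@H]2[C@@H](OC(=O)[C@]23CC(c2ccccc2Br)=NO3)[C@]2(C)C(=O)C=C[C@@]12O` gives 2.22; the one change between these two compounds, 2-bromophenyl in place of 4-methoxyphenyl on a carbon with a double bond to nitrogen, brings a number 0.75 log units higher from compound 1 to compound 2 (beyond the scatter). Compound 3 `C[C@H]1CC[C@@H]2[C@@H](OC(=O)[C@]23CC(c2ccc(Cl)cc2)N(c2ccccc2)O3)[C@]2(C)C(=O)C=C[C@@]12O` gives 3.87, the highest of the three numbers, standing well beyond the scatter above both compound 2 and compound 1. Compound 3 differs from compound 2 in more than one place, so that gap cannot be tied to a single change.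

Compound 4 `C[C@H]1CC[C@@H]2[C@@H](OC(=O)[C@]23CC(c2c(F)c(F)c(F)c(F)c2F)N(c2ccccc2)O3)[C@]2(C)C(=O)C=C[C@@]12O` has not yet been measured in this assay. It differs from compound 3 in one place only: 2,3,4,5,6-pentafluorophenyl in place of 4-chlorophenyl on a saturated ring carbon. For the measured compounds named here, no measured step swaps one ring for another on a saturated ring carbon. Going by the values given here, the only measured ring swap, from compound 1 to compound 2, is on a carbon with a double bond to nitrogen and was modest in size. With such thin guidance, the expected change is a step of about a number 0.03 log units higher from compound 3 to compound 4 (within the scatter), within the scatter. Compound 4 is therefore estimated at 3.9, with a likely range from 3.3 to 4.5.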

Compound 4, partition coefficient: 3.72
The estimate for compound 4 lay 0.18 log units above the measured number; the measured number falls inside the stated range.
By their numbers in this assay, from the lowest: compound 1; then compound 2; then compounds 4 and 3 (each within the scatter of the next).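

Among the compounds shown here, this is the first ring swap measured on a saturated ring carbon, here next to the ring nitrogen: in this assay, 2,3,4,5,6-pentafluorophenyl in place of 4-chlorophenyl gives a number 0.15 log units lower from compound 3 to compound 4 (within the scatter). Five fluorine atoms in place of one chlorine, with the entering group at 11 heavy atoms against 7, therefore leave no change in this read-out that can be told from the scatter, whereas the one earlier ring swap, on a carbon with a double bond to nitrogen and with other ring groups, gave a number 0.75 log units higher from compound 1 to compound 2 (beyond the scatter). Nothing measured here explains why this swap leaves the number within the scatter.

Both rings compared at this position are six-membered aromatic rings of carbon only, with no hydrogen-bond donors or acceptors, so the compounds shown leave open how far the number would move with an amine, a carboxylic acid or a longer chain on this saturated ring carbon. Also open, going by these compounds, is how much of the gap between compound 2 and compound 3 belongs to any one of their several differences.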